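Furan cyanoacrylamides: a bromo step in growth inhibition

A few compounds are considered here, and "the series" means these few. Any claim that something is new, unique, unknown or untested is made for them only; others in the source may bear on it.

Three cyanoacrylic compounds carry a number in a functional assay on HT-29 cells (Homo sapiens) for inhibition, read by MTT assay, with a stated time of 72 h; on this read-out higher numbers stand for weaker inhibition of growth and lower numbers for stronger inhibition of growth. Compound 1 `N#C/C(=C\c1c[nH]c2ccccc12)C(=O)c1c[nH]c2ccccc12` gives 6000 nM. Compound 2 `N#C/C(=C\c1ccc[nH]1)C(=O)NCc1ccc(Cl)c(Cl)c1` gives 85000 nM. Compound 3 `COc1ccc(CNC(=O)/C(C#N)=C/c2ccco2)cc1` gives 22000 nM, the second highest of the three numbers; it lies beyond the scatter on both sides, with compound 1 at the lower number and compound 2 at the higher one. No two of these compounds differ in one place only, so no single-point step can be read from them.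

Compound 4 `COc1ccc(CNC(=O)/C(C#N)=C/c2ccc(Br)o2)cc1` is the next member and is unmeasured. It differs from compound 3 by bromo in place of hydrogen on an aromatic carbon, furan-2-yl becoming 5-bromofuran-2-yl. Within the data shown here, none of the measured compounds shows what a halogen on this ring does, and compounds 1 and 2 change both the amide side and the ring relative to compound 3, so they give no guide to the size of this step. Since the change adds a single heavy atom, the step in this assay from compound 3 to compound 4 is expected to be a 1.6-fold lower number from compound 3 to compound 4 (0.20 log units; within the scatter), a modest move toward stronger inhibition that may not clear the scatter. Compound 4 is therefore estimated at 14000 nM, with a range from 5000 nM to 40000 nM.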

Compound 4, concentration for 50% growth inhibition: 10000 nM
Beside the measured number, compound 4's estimate is 1.4-fold (0.15 log units) above it, within the range that was stated.
By their numbers in this assay, from the lowest: compounds 1 and 4 (each within the scatter of the next); then compound 3; then compound 2.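

In this assay, among these compounds, the first single-place step gives a 2.2-fold lower number from compound 3 to compound 4 (0.34 log units; beyond the scatter), with bromo in place of hydrogen on the aromatic carbon next to the ring oxygen. This shows that the position is not indifferent to substitution: furan-2-yl becoming 5-bromofuran-2-yl moves the number toward stronger inhibition of growth, although the step is modest and rests on this one pair with the 4-methoxybenzyl amide side kept constant. No measurement shown gives a reason for the step, so it stands as an observation only.

The compounds shown leave open whether the gain belongs to bromo itself or would also appear with another group at this carbon, such as a methyl, an amine or a carboxylic acid. They also leave open whether bromo would give a step of similar size on the core of compound 2 or with a different amide side, so the effect cannot yet be extended beyond this pair.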